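Piperidinyl to methylpiperazinyl at the end of the propyl chain

This account rests on a few compounds, and the source may have more. Where it says the series, first, only, none or still open, it means among the compounds named here.

In a functional assay on HT-29 cells (Homo sapiens) for inhibition, read by MTT assay, with a stated time of 72 h (on this read-out higher numbers stand for weaker inhibition and lower numbers for stronger inhibition), compound 1 `COc1cc2c(Oc3ccc(NC(=O)c4nn(-c5ccccc5C(F)(F)F)c(=O)cc4C)cc3F)ccnc2cc1OCCCN1CCN(C)CC1` gives 170 nM.
In this assay compound 2 `COc1cc2c(Oc3ccc(NC(=O)c4nn(-c5ccccc5OC(F)(F)F)c(=O)cc4C)cc3F)ccnc2cc1OCCCN1CCN(C)CC1` gives 180 nM.
In this assay compound 3 `COc1cc2c(Oc3ccc(NC(=O)c4nn(-c5ccc(Cl)cc5)c(=O)cc4C)cc3F)ccnc2cc1OCCCN1CCCCC1` gives 360 nM.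

Compound 3 has the highest number of the three, but its gap to compound 2 is within the scatter, while its gap to compound 1 lies beyond it. Compound 4 `COc1cc2c(Oc3ccc(NC(=O)c4nn(-c5ccc(Cl)cc5)c(=O)cc4C)cc3F)ccnc2cc1OCCCN1CCN(C)CC1` differs from compound 3 in one place: 4-methylpiperazin-1-yl in place of piperidin-1-yl on a saturated chain carbon, three bonds along the chain from an oxygen on an aromatic ring. Among the compounds with values here, the only measured step, a 1.1-fold higher number from compound 1 to compound 2 (0.02 log units; within the scatter), concerns a different part of the molecule and says nothing about this change. Within the data shown here, compounds 1 and 2 carry the entering group, yet they also differ from compound 3 elsewhere, so no single step isolates it. With no direct evidence, the step is expected to stay within the scatter: a 1.2-fold lower number from compound 3 to compound 4 (0.08 log units; within the scatter). Compound 4 is therefore estimated at 300 nM, with a range from 150 nM to 600 nM.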

Compound 4, half-maximal inhibitory concentration: 320 nM
The estimate for compound 4 lay 1.1-fold (0.03 log units) below the measured number; the range from low to high includes it.
By their numbers in this assay, from the lowest: compounds 1, 2, 4 and 3 (each within the scatter of the next, the first and the last beyond it).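

In this assay, 4-methylpiperazin-1-yl in place of piperidin-1-yl at the end of the propyl chain gives a 1.1-fold lower number from compound 3 to compound 4 (0.05 log units; within the scatter), so this exchange shows no clear effect with the 4-chlorophenyl group present. Compound 4 also allows that aromatic nitrogen substituent to be read alone: 4-chlorophenyl in place of 2-(trifluoromethoxy)phenyl gives a 1.8-fold higher number from compound 2 to compound 4 (0.25 log units; within the scatter), and in place of 2-(trifluoromethyl)phenyl it gives a 1.9-fold higher number from compound 1 to compound 4 (0.27 log units; within the scatter). No measurement shown here offers an explanation for these steps. Still open, from the compounds shown here alone, is whether morpholin-4-yl, an unsubstituted piperazine or a butyl chain in place of the propyl chain would also stay within the scatter of compound 3.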